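Series notes: benzofuranyl against ethynyl on the shared core

The source may report more compounds than this note shows. Statements on the series, on what has been measured and on what is new or still open speak of the compounds shown alone.

Measured values in a functional assay on HepG2 cells (Homo sapiens) for antiproliferative activity, read by XTT assay, with a stated time of 72 h; a higher number here means a weaker inhibitor, a lower number a stronger inhibitor:
Compound 1 `C#Cc1cn([C@@H]2O[C@H](CO)[C@@H](O)[C@H]2O)c2ncnc(OC)c12` gives 12700 nM in this assay.
Compound 2 `CN(C)c1ncnc2c1c(-c1cc3ccccc3o1)cn2[C@@H]1O[C@H](CO)[C@@H](O)[C@H]1O` reaches only the assay limit of > 20000 nM in this assay.
Compound 3 `Cc1ncnc2c1c(-c1cc3ccccc3o1)cn2[C@@H]1O[C@H](CO)[C@@H](O)[C@H]1O` also reaches only the assay limit of > 20000 nM in this assay.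

Compound 3 thus stands at the limit, not at a number, and its step that the two limits leave unreadable from compound 2 to compound 3 is unreadable because of the limit of > 20000 nM in this assay, at which 2 of the 3 values shown sit. The only numbered anchor in the set is compound 1.

Compound 4 `C#Cc1cn([C@@H]2O[C@H](CO)[C@@H](O)[C@H]2O)c2ncnc(C)c12` differs from compound 3 by ethynyl in place of 1-benzofuran-2-yl on an aromatic carbon. For the measured compounds named here, no measured step touches this position; the single measured step, a step that the two limits leave unreadable from compound 2 to compound 3, alters a group elsewhere on the core and gives no size. Compound 4 combines the ethynyl of compound 1 with the methyl of compound 3. Compound 1 with ethynyl and methoxy gives 12700 nM. Compound 4 is expected to sit in a similar weak region, so the step of an at least 1.3-fold lower number from compound 3 to compound 4 (0.12 log units; that floor lies within the scatter) is estimated to move from the limit toward a readable number. Compound 4 is estimated at 15000 nM, within 6000 nM to 40000 nM, with a real chance of another limit.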

Compound 4, half-maximal inhibitory concentration: 290 nM
The estimate for compound 4 lay 52-fold (1.71 log units) above the measured number, and the stated range ends above it.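

The position on the five-membered aromatic ring, two ring bonds from the ring nitrogen, now gives a readable change in this assay: ethynyl in place of 1-benzofuran-2-yl gives an at least 68-fold lower number from compound 3 to compound 4 (1.83 log units; beyond the scatter). That size is only a floor, because compound 3 stands at a limit of the assay: the limit of > 20000 nM in this assay, at which 2 of the 4 values shown sit.

With ethynyl held fixed, the group on the core's other substituted aromatic carbon also matters, as methyl in place of methoxy gives a 44-fold lower number from compound 1 to compound 4 (1.64 log units; beyond the scatter), so ethynyl alone does not set the value.

Still open, going by these compounds, is whether a nitrile or a longer chain such as prop-1-ynyl at the ethynyl position would keep the value of compound 4. Also open, on these data alone, is how ethyl, chloro or dimethylamino in place of methyl would read alongside ethynyl.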